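The compounds below may be only part of what the source reports. "The series", "measured", "known", "first", "only" and "open" are said of these compounds alone.

Compound 2 `O[C@H](c1ccccn1)[C@]1(c2cccc(C(F)(F)F)c2)C[C@H](O)C1` and compound 1 `O[C@H](c1ccccn1)[C@]1(c2cccc(OC(F)(F)F)c2)C[C@H](O)C1` share one core and differ by trifluoromethoxy in place of trifluoromethyl on an aromatic carbon. In an ADME assay on liver for metabolic stability, with Liver microsome (Homo sapiens) as the target, read by LC-MS, using microsomes, with a stated time of 5 h (a lower number here means slower removal, a higher number faster removal of the compound), compound 2 gives 133 mL/min/kg, and compound 1 gives 150 mL/min/kg, so that a 1.1-fold higher number from compound 2 to compound 1 (0.05 log units; within the scatter). Compound 3 `C[C@]1(O)C[C@@](c2ccc(C(F)(F)F)cc2)([C@H](O)c2ccccn2)C1` is built on another core; the difference between the two cores is not broken down here. In this assay compound 3 gives 50 mL/min/kg, the lowest of the three numbers and beyond the scatter from both others. Compound 4 `C[C@]1(O)C[C@@](c2ccc(OC(F)(F)F)cc2)([C@H](O)c2ccccn2)C1` has not yet been measured in this assay and is related to compound 3 by trifluoromethoxy in place of trifluoromethyl on an aromatic carbon. This is the same kind of change as that from compound 2 to compound 1, though the place differs: meta to a large group there, para to a large group here. The earlier step, a 1.1-fold higher number from compound 2 to compound 1 (0.05 log units; within the scatter), lay within the scatter. On that basis a step of similar size is expected, a 1.1-fold higher number from compound 3 to compound 4 (0.04 log units; within the scatter). Compound 4 is therefore estimated at 55 mL/min/kg, with a likely range from 30 mL/min/kg to 100 mL/min/kg.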

Compound 4, clearance: 66.7 mL/min/kg
The estimate for compound 4 lay 1.2-fold (0.08 log units) below the measured number; low and high end bracket the measured number.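

In this assay the new step is a 1.3-fold higher number from compound 3 to compound 4 (0.13 log units; within the scatter), so trifluoromethoxy in place of trifluoromethyl stays within the scatter on this core as well. The change reads alike on both cores, with no difference beyond the scatter between the two steps: the same change on two cores in this assay, a 1.1-fold higher number (0.05 log units; within the scatter) from compound 2 to compound 1 and a 1.3-fold higher number (0.13 log units; within the scatter) from compound 3 to compound 4, 1.2-fold (0.07 log units) apart, within the scatter of two such steps. This rests on two pairs only, which also differ in where the group sits, so it shows no more than that the change carried over here and says nothing about any third core.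

Open, on these data alone, is how other groups on this aromatic carbon would read, such as a nitrile, an amine or a carboxylic acid. Also open, as far as these compounds go, is how trifluoromethyl and trifluoromethoxy compare in any other assay.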